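Difluoromethyl ether series: free hydroxy analogue pending

The source may report more compounds than this note shows. Statements on the series, on what has been measured and on what is new or still open speak of the compounds shown alone.

Measured so far in a functional assay on HL-60 cells (Homo sapiens) for inhibition, read by MTT assay; a lower number here means a stronger inhibitor of growth, a higher number a weaker inhibitor of growth:
- compound 1 `O=c1c(-c2ccc(OC(F)F)cc2)coc2cc(OC(F)F)cc(O)c12`: 5.5 uM
- compound 2 `CCCCCCCCCCOc1ccc(-c2coc3cc(OCCCCCCCCCC)cc(O)c3c2=O)cc1`: 3.09 uM

Compound 1 carries the higher of the two numbers, but compound 2 sits within the usual scatter of it, so nothing can be said about order between them. Within the data shown here, no pair of measured compounds differs in a single place, so there is no measured step in this assay to lean on for the next change.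

Compound 3 `O=c1c(-c2ccc(O)cc2)coc2cc(OC(F)F)cc(O)c12` is the analogue in which one difluoromethyl ether of compound 1 is opened to the free hydroxy: hydrogen in place of difluoromethyl on an oxygen on an aromatic ring. With nothing in the measured pair bearing on this change, the step from compound 1 to compound 3 in this assay is expected to be no change at the digits printed from compound 1 to compound 3 (within the scatter), that is, none beyond the scatter, with no preferred direction. For compound 3 the estimated value in this assay is 5.5 uM, with a range of 2 uM to 15 uM.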

Compound 3, concentration for growth inhibition (reported as GI): 3.53 uM
Beside the measured number, compound 3's estimate is 1.6-fold (0.19 log units) above it; the range from low to high includes it.
By their numbers in this assay, from the lowest: compounds 2, 3 and 1 (each within the scatter of the next).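

In this assay, among these compounds, hydrogen in place of difluoromethyl on an oxygen on an aromatic ring gives a 1.6-fold lower number from compound 1 to compound 3 (0.19 log units; within the scatter) and is the first single-place step. At this place, difluoromethoxy and hydroxy therefore cannot be told apart in this read-out, and growth inhibition survives the loss of the difluoromethyl group. No available measurement bears on why the two groups read alike.

As far as these compounds go, compound 3 still carries its other difluoromethoxy group, so the effect of hydroxy there, and of hydroxy at both places, remains open. Also open, from the compounds shown here alone, is whether a methyl or an acetyl on the same oxygen would give a step beyond the scatter.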